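A few compounds are considered here, and "the series" means these few. Any claim that something is new, unique, unknown or untested is made for them only; others in the source may bear on it.

Measured compounds in a functional assay on HT-29 cells (Homo sapiens) for inhibition, read by sulforhodamine B assay, with a stated time of 72 h; on this read-out lower numbers stand for stronger inhibition and higher numbers for weaker inhibition:
- Compound 1 `CCC(C)NC(=C\C(=O)/C=C/c1ccc(OC(C)=O)c(OC)c1)/C=C/c1ccc(OC(C)=O)c(OC)c1` returns only a limit, > 25000 nM.
- Compound 2 `C=CCNC(=C\C(=O)/C=C/c1ccc(O)c(OC)c1)/C=C/c1ccc(O)c(OC)c1` gives 24600 nM.
- Compound 3 `CCC(C)NC(=C\C(=O)/C=C/c1ccc(O)cc1)/C=C/c1ccc(O)cc1` gives 15600 nM.

The limit for compound 1 is the edge of what this assay can report, not a number; it is the point described by the limit of > 25000 nM in this assay, at which 1 of the 3 values shown sits. Among the two actual numbers, compound 2 holds the higher one, yet its gap to compound 3 is within the usual scatter of repeated runs, so the two compounds cannot be told apart on this read-out.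

Compound 4 `COc1cc(/C=C/C(=O)/C=C(/C=C/c2ccc(O)c(OC)c2)NC2CCCCC2)ccc1O` has not yet been measured. It differs from compound 2 in one place: cyclohexyl in place of allyl on an amine nitrogen. Among the measured compounds shown here, no pair of measured compounds separated by a single change is available, so there is no measured step to lean on. Given that compound 2 sits at 24600 nM, the expected step of a 1.6-fold lower number from compound 2 to compound 4 (0.21 log units; within the scatter) is none beyond the scatter in this assay. Compound 4 is therefore estimated at 15000 nM, with a range from 5000 nM to 40000 nM.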

Compound 4, half-maximal inhibitory concentration: > 25000 nM
Compound 4 ended at the assay's limit; the forecaster's own chance of this, stated with the estimate: 25%; at least 1.6-fold (0.22 log units) between middle value and limit.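

In this assay compound 4 returns only a limit (> 25000 nM) and not a number. Among the compounds shown here, that gives the first readable step at this amine nitrogen (an at least 1.0-fold higher number from compound 2 to compound 4 (0.00 log units; that floor lies within the scatter)), and because it is only a floor, it shows just that cyclohexyl in place of allyl brings no sign of stronger inhibition. The evidence for this rests on the edge of the assay, where little room remains to see any further weakening: the limit of > 25000 nM in this assay, at which 2 of the 4 values shown sit.

On these data alone, how far compound 4 really lies past that limit stays open, so the size of the change from allyl to cyclohexyl cannot be read. Also open, as far as these compounds go, is whether a benzyl group, or a longer chain ending in an amine, on this same nitrogen would give a number clearly lower than that of compound 2.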